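The source may hold more compounds than are shown below. What is called first, only, known or untested is meant among the compounds shown, and "the series" means these compounds.

Measured so far:
- compound 1, `COc1ccc(CN2CCC3(CC2)OC(OC)Cc2c3cnn2-c2ccccc2)cc1`: 1.5 nM
- compound 2, `COC1Cc2c(cnn2-c2ccccc2)C2(CCN(CCCCc3ccccc3)CC2)O1`: 3.2 nM

Among the measured compounds shown here, in an assay for displacement of a labelled ligand from Sigma non-opioid intracellular receptor 1 (Cavia porcellus), read by scintillation counting, with a stated time of 180 min (a lower number here means a stronger inhibitor, a higher number a weaker inhibitor), compound 1 holds the lowest of the two numbers, and the one measured step, a 2.1-fold higher number from compound 1 to compound 2 (0.33 log units; beyond the scatter), runs upward. Compound 3, `CCCCCN1CCC2(CC1)OC(OC)Cc1c2cnn1-c1ccccc1`, differs from compound 1 in one place: butyl in place of 4-methoxyphenyl on a saturated chain carbon bound to an amine nitrogen in a ring. The measured step bears on this change only loosely, since there 3-phenylpropyl entered rather than butyl, yet both remove the 4-methoxyphenyl from the same saturated chain carbon. A modest rise of similar size is therefore expected, a 2.7-fold higher number from compound 1 to compound 3 (0.43 log units; beyond the scatter). For compound 3 the estimate is 4 nM, ranging from 1.5 nM to 12 nM.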

Compound 3, inhibition constant: 0.82 nM
Compound 3: the middle estimate sits 4.9-fold (0.69 log units) above what was measured; the measured number lies below the stated range.
By their numbers in this assay, from the lowest: compounds 3 and 1 (each within the scatter of the next); then compound 2.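

On the saturated chain carbon bound to an amine nitrogen in a ring, butyl in place of 4-methoxyphenyl gives a 1.8-fold lower number from compound 1 to compound 3 (0.26 log units; within the scatter), so in this pair the six-membered aromatic ring is not needed for a low number. Further out on the chain, methyl in place of phenyl gives a 3.9-fold lower number from compound 2 to compound 3 (0.59 log units; beyond the scatter), so a plain pentyl chain does better here than the chain ending in phenyl in compound 2. No available evidence explains either step.

Still open, going by these compounds, is whether a shorter propyl chain or a longer heptyl chain would keep the number this low. Also open, on these data alone, is what a hydroxyl group or an amine at the end of the pentyl chain would do.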